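Fluorine on a Pendant Phenyl Ring in Two Purine Series

The source may report more compounds than this note shows. Statements on the series, on what has been measured and on what is new or still open speak of the compounds shown alone.

Within the data shown here, the first pair of compounds shares a core carrying a benzyl group. Compound 1, `Clc1ncnc2c1ncn2Cc1ccccc1`, was tested in an assay on isolated protein for inhibition of RAC-alpha serine/threonine-protein kinase (Homo sapiens), tested at 30 uM (a higher number here means more inhibition at the concentration tested (going by the name of the read-out), a lower number less inhibition), where compound 1 gives 0%. Compound 2, `Fc1ccc(Cn2cnc3c(Cl)ncnc32)cc1`, differs from compound 1 by fluoro in place of hydrogen on an aromatic carbon, and in this assay compound 2 gives 0%. The step is no change at the digits printed from compound 1 to compound 2 (within the scatter).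

Compound 3, `Cn1c(-c2ccccc2)nc2c(Sc3ccccc3)ncnc21`, belongs to a second series; the difference between its core and the core of compound 1 is not broken down here. In this assay compound 3 gives 42%, the highest of the three measured numbers, and its distance to both compound 1 and compound 2 lies beyond the usual scatter.

Compound 4, `Cn1c(-c2ccccc2)nc2c(Sc3ccc(F)cc3)ncnc21`, has not yet been measured. It differs from compound 3 by fluoro in place of hydrogen on an aromatic carbon, and since the place is described in the same words as for the change from compound 1 to compound 2, this is the same change made on a different core.

Among the measured compounds shown here, the only measured instance of this change, from compound 1 to compound 2, showed no change within the scatter, so for compound 4 a step of about no change at the digits printed from compound 3 to compound 4 (within the scatter) is expected in this assay, resting on no change at the digits printed from compound 1 to compound 2 (within the scatter) and on the value of compound 3, 42%. Compound 4 is therefore estimated to give 42% in this assay, expected to fall between 25% and 60%.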

Compound 4, a percentage reported as inhibition, at one concentration (the size of the read-out at that concentration, not a potency): 29%
The estimate for compound 4 lay 13 percentage points above the measured number; the measured number falls inside the stated range.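

On the second core, putting fluoro in place of hydrogen on an aromatic carbon gives a number 13 percentage points lower from compound 3 to compound 4 (beyond the scatter) in this assay. Set beside the same change on the first core, this step cannot be told apart from the earlier one, so the two cores give no measurable sign that the change behaves differently from one to the other: the same change on two cores in this assay, no change at the digits printed (within the scatter) from compound 1 to compound 2 and a number 13 percentage points lower (beyond the scatter) from compound 3 to compound 4, 13 percentage points apart, within the scatter of two such steps. This does not show that the change carries over unaltered, since the comparison rests on a single pair for each core, and in the first pair compound 1 and compound 2 both print a value of zero, so that pair offers little basis for judging how large a step might be on a core with a measurable read-out.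

The compounds shown leave open how a chloro group, a methoxy group or an amine would read in the same place on the phenylsulfanyl ring of compound 3. They also leave open whether fluoro on the other phenyl ring of compound 3 would give a similar step, and whether a step of this size would recur on further pairs.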